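The source may report more compounds than this note shows. Statements on the series, on what has been measured and on what is new or still open speak of the compounds shown alone.

Working notes on the series. Compound 1 `CCn1c(-c2ccccc2)nc2c(NC3CCC3)ncnc21` and compound 2 `CCCn1c(-c2ccccc2)nc2c(NC3CCC3)ncnc21` share one core; compound 3 `Cn1c(-c2ccccc2)nc2c(NC3CCCC3)ncnc21` and compound 4 `CCn1c(-c2ccccc2)nc2c(NC3CCCC3)ncnc21` share another. How the two cores differ is not broken down here. In an assay on CHO cells for displacement of a labelled ligand from adenosine receptor A1 (Homo sapiens), read by scintillation counting, with a stated time of 3 h (a lower number here means a stronger inhibitor, a higher number a weaker inhibitor), compound 1 gives 6 nM, compound 2 gives 15 nM, and compound 3 gives 2.8 nM, the lowest number of the three measured. The measured step of a 2.5-fold higher number from compound 1 to compound 2 (0.40 log units; beyond the scatter) is the change (methyl in place of hydrogen on a saturated chain carbon, two bonds along the chain from an aromatic nitrogen).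

Compound 4 is not yet measured in this assay. It differs from compound 3 by methyl in place of hydrogen on a saturated chain carbon bound to an aromatic nitrogen. This is the same kind of change as that from compound 1 to compound 2, but not the same: the earlier one sits two bonds along the chain from an aromatic nitrogen, whereas this one sits on a saturated chain carbon bound to an aromatic nitrogen. Among the measured compounds shown here, only one instance of the earlier change is available, and none at this place, so the expectation rests loosely on it: the step from compound 3 to compound 4 in this assay is expected to be small, a 1.4-fold higher number from compound 3 to compound 4 (0.15 log units; within the scatter), perhaps less costly than the earlier step because a 2.5-fold higher number from compound 1 to compound 2 (0.40 log units; beyond the scatter) lies further out on the chain. For compound 4 the estimated value is 4 nM, within 1.5 nM to 10 nM.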

Compound 4, inhibition constant: 3.9 nM
Compound 4: middle estimate off by 1.0-fold (0.01 log units), on the high side, and the stated range covers the measured number.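

In this assay the methyl in place of hydrogen on a saturated chain carbon bound to an aromatic nitrogen gives a 1.4-fold higher number from compound 3 to compound 4 (0.14 log units; within the scatter) and reads alike with the earlier step on the other core: the same change on two cores in this assay, a 2.5-fold higher number (0.40 log units; beyond the scatter) from compound 1 to compound 2 and a 1.4-fold higher number (0.14 log units; within the scatter) from compound 3 to compound 4, 1.8-fold (0.25 log units) apart, within the scatter of two such steps. Within these two pairs the change carries from one core to the other without a measured difference, but this rests on a single pair per core, and the added methyl sits at a different place on the chain in each pair, so the effect of the core cannot be separated from that of the place. The cyclopentyl in place of cyclobutyl on a nitrogen on an aromatic ring gives a 1.5-fold lower number from compound 1 to compound 4 (0.19 log units; within the scatter) and shows that this one exchange also stays within the scatter, not that it would do so with other chains.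

Open, going by these compounds, is how a longer chain such as butyl or a branched chain such as isopropyl would read on either core. Also open, on these data alone, is whether a chain ending in an amine or a carboxylic acid would keep the steps this small.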